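Hydroxamic anilide series: chloro to hydrogen on the aryl ring

The compounds below may be only part of what the source reports. "The series", "measured", "known", "first", "only" and "open" are said of these compounds alone.

Compound 3 `O=C(CC1CCCCC1)N(O)c1ccc(Cl)cc1` gives 33000 nM in a functional assay on MOLT-4 cells (Homo sapiens) for inhibition (a lower number here means a stronger inhibitor, a higher number a weaker inhibitor), the highest of the three numbers, though both neighbours sit within the scatter: compound 2 `O=C(CCC1CCCC1)N(O)c1ccc(Cl)cc1` gives 28000 nM and compound 1 `O=C(C1CC1)N(O)c1ccc(Cl)cc1` gives 24000 nM. Among the measured compounds shown here, the only recorded step, a 1.2-fold higher number from compound 2 to compound 3 (0.07 log units; within the scatter), concerns the acyl side and not the aryl ring. Compound 4 `O=C(CC1CCCCC1)N(O)c1ccccc1` differs from compound 3 by hydrogen in place of chloro on an aromatic carbon. For the measured compounds named here, no measured step touches the chloro group, so nothing in the set sizes this change, and the three numbers themselves spread less than the scatter. For compound 4 the expected step is therefore a 1.2-fold higher number from compound 3 to compound 4 (0.08 log units; within the scatter), with no direction resolvable beyond the scatter. Compound 4 is estimated at 40000 nM in this assay, range 15000 nM to 110000 nM.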

Compound 4, half-maximal inhibitory concentration: 41000 nM
Compound 4: the middle estimate sits 1.0-fold (0.01 log units) below what was measured; measured number inside the range.
By their numbers in this assay, from the lowest: compounds 1, 2, 3 and 4 (each within the scatter of the next).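

Among the compounds shown here, the chloro position now has a measured step: with hydrogen in place of chloro on this aromatic carbon, this assay shows a 1.2-fold higher number from compound 3 to compound 4 (0.09 log units; within the scatter), the first reading of this change. In this pair, the chloro group is therefore not required to keep the number at this level. No available evidence bears on the reason for this result.

As far as these compounds go, it remains open whether an amine or a methoxy group at this position would separate from chloro and hydrogen beyond the scatter. The same change on the acyl side of compound 1 or compound 2 is also unresolved.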